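Taking the bromo off compound 2

This account rests on a few compounds, and the source may have more. Where it says the series, first, only, none or still open, it means among the compounds named here.

Compound 1 `CC(C)(C)NCc1c(C(=O)O)nn(-c2ccc(Cl)cc2)c1-c1ccc(F)cc1` gives > 623000 nM (a limit)
Compound 2 `CC(C)(C)NCc1c(C(=O)O)nn(-c2ccc(Cl)cc2)c1-c1ccc(Br)cc1` gives > 542000 nM (a limit)

Compound 2 stands only at a limit: in a functional assay on U-251 cells (Homo sapiens) for inhibition, read by sulforhodamine B assay, with a stated time of 48 h (on this read-out higher numbers stand for weaker inhibition of growth and lower numbers for stronger inhibition of growth), compound 2 gives > 542000 nM as a limit and not as a number. Going by the values given here, the one other value known, that of compound 1, is a limit as well. Compound 3 `CC(C)(C)NCc1c(C(=O)O)nn(-c2ccc(Cl)cc2)c1-c1ccccc1` keeps the rest of compound 2 and changes in a single place. The change is hydrogen in place of bromo on an aromatic carbon in words hydrogen in place of bromo on an aromatic carbon, or 4-bromophenyl to phenyl. Among the compounds with values here, only one measured step bears on this, a step that the two limits leave unreadable from compound 1 to compound 2 with bromo in place of fluoro on an aromatic carbon. It offers no size to carry over, so no step beyond the usual scatter is expected in this assay and another limit is the likeliest report. Compound 3 is estimated at 640000 nM with an expected range from 300000 nM to 900000 nM in this read-out. The estimate implies a step that the limit leaves unreadable from compound 2 to compound 3 as the expected step.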

Compound 3, concentration for 50% growth inhibition: > 652000 nM
Compound 3: no number, only a limit; the forecaster's own chance of this, stated with the estimate: 85%; middle value at least 1.0-fold (0.00 log units) away from the limit.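

Going by these compounds alone, compound 3, like compound 1 and compound 2, is reported only as a limit, and no step among the three can be read in this assay. The compounds shown leave open whether hydrogen, fluoro or bromo at this place changes growth inhibition at all, and what actual value any of the three would have.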